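Swapping the Triazole Arm While Keeping the Fluoroethoxy Sulfonyl

This account rests on a few compounds, and the source may have more. Where it says the series, first, only, none or still open, it means among the compounds named here.

Two hydroxamic acids sharing one core have been measured in an assay on isolated protein for inhibition of matrix metalloproteinase-9 (Homo sapiens), read by fluorescence, with a stated time of 30 min; on this read-out higher numbers stand for weaker inhibition and lower numbers for stronger inhibition. Compound 1 `COc1ccc(S(=O)(=O)N(CCn2cc(CNS(=O)(=O)c3ccc(F)cc3)nn2)[C@@H](C(=O)NO)C(C)C)cc1` gives 0.6 nM in this assay. Compound 2 `CC(C)[C@H](C(=O)NO)N(CCn1cc(CCCCOc2cccnc2F)nn1)S(=O)(=O)c1ccc(OCCF)cc1` gives 0.8 nM in this assay. Of the two numbers, that of compound 2 is not separated from that of compound 1 beyond the usual scatter, so the two stand together at the low end of the range seen so far.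

Compound 3 `CC(C)[C@H](C(=O)NO)N(CCn1cc(CNS(=O)(=O)c2ccc(F)cc2)nn1)S(=O)(=O)c1ccc(OCCF)cc1` has not yet been measured. It differs from compound 2 by a group of 11 heavy atoms (6 carbon, 1 nitrogen, 2 oxygen, 1 fluorine, 1 sulfur; one six-membered aromatic ring of carbon only) in place of a group of 11 heavy atoms (8 carbon, 1 nitrogen, 1 oxygen, 1 fluorine; one six-membered aromatic ring with 1 hetero atom), on a saturated chain carbon bound to an aromatic carbon. In effect, compound 3 carries the triazole arm of compound 1 and the fluoroethoxy aryl sulfonyl of compound 2.

Both arms occur in compounds whose numbers lie within the scatter of one another, so no step beyond the scatter is expected in this assay from compound 2 to compound 3, and the estimated step is a 1.3-fold lower number from compound 2 to compound 3 (0.12 log units; within the scatter). On that basis compound 3 is expected to give about 0.6 nM in this assay, with a plausible range from 0.25 nM to 1.5 nM.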

Compound 3, half-maximal inhibitory concentration: 3 nM
Compound 3: middle estimate off by 5.0-fold (0.70 log units), on the low side; the measured number lies above the stated range.
By their numbers in this assay, from the lowest: compounds 1 and 2 (each within the scatter of the next); then compound 3.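

In this assay, the ((4-fluorophenyl)sulfonyl)amino group entering on a saturated chain carbon bound to an aromatic carbon, in place of the group with a six-membered aromatic ring with 1 hetero atom, gives a 3.8-fold higher number from compound 2 to compound 3 (0.57 log units; beyond the scatter) and so shows that the two arms are not interchangeable at this position when the fluoroethoxy aryl sulfonyl is kept. Fluoromethyl in place of hydrogen on a saturated chain carbon bound to an oxygen on an aromatic ring gives a 5.0-fold higher number from compound 1 to compound 3 (0.70 log units; beyond the scatter) and so shows that this second change also moves the number when the arm of compound 1 is kept, something the closeness of compound 1 and compound 2 could not reveal, since those two differ in more than one place. Nothing available here speaks to the origin of either step.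

The compounds shown leave open whether fluoromethyl in place of hydrogen would produce a similar step on the arm of compound 2. They also leave open what an amine, a carboxylic acid or a longer chain would give in place of the ((4-fluorophenyl)sulfonyl)amino group on that saturated chain carbon.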